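Opening an Amine Ring on the Chromone Side Chain

This account rests on a few compounds, and the source may have more. Where it says the series, first, only, none or still open, it means among the compounds named here.

Among the compounds with values here, compound 3 `O=c1cc(-c2ccccc2)oc2cc(OCc3ccccc3)c(OCCCCN3CCCC3)c(O)c12` stands second highest of the three numbers so far in a functional assay on BCG823 cells (Homo sapiens) for antiproliferative activity, read by MTT assay, with a stated time of 48 h (a lower number here means a stronger inhibitor, a higher number a weaker inhibitor), where compound 3 gives 3200 nM. Its nearest neighbour is compound 1 `O=c1cc(-c2ccccc2)oc2cc(OCc3ccccc3)c(OCCCCN3CCCCC3)c(O)c12`, which in this assay gives 3000 nM; the step of a 1.1-fold higher number from compound 1 to compound 3 (0.03 log units; within the scatter) lies within the scatter. Within the data shown here, the furthest is compound 2 `CCN(CC)CCCCOc1c(OC)cc2oc(-c3ccccc3)cc(=O)c2c1O`, which gives 17400 nM in this assay, but compound 2 differs from compound 3 in two places, so its number shows only that this pair of changes together leaves a much weaker inhibitor.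

Compound 4 `CCN(CC)CCCCOc1c(OCc2ccccc2)cc2oc(-c3ccccc3)cc(=O)c2c1O` is not yet measured. The change from compound 3 to compound 4 is diethylamino in place of pyrrolidin-1-yl on a saturated chain carbon, four bonds along the chain from an oxygen on an aromatic ring. Among the measured compounds shown here, the only measured step that bears on the amine end of the chain is the exchange of one saturated ring for another, from compound 1 to compound 3, and it moved the number hardly at all. Opening the ring to an acyclic amine of the same heavy-atom count is a change of similar kind, and no measured step shows a large effect of it in isolation. Compound 4 is therefore expected to sit close to compound 3, with a step of a 1.3-fold higher number from compound 3 to compound 4 (0.10 log units; within the scatter) that is expected to stay within the scatter. The estimate for compound 4 in this assay is 4000 nM, with a range from 1500 nM to 12000 nM.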

Compound 4, half-maximal inhibitory concentration: 4200 nM
The estimate for compound 4 lay 1.1-fold (0.02 log units) below the measured number; low and high end bracket the measured number.
By their numbers in this assay, from the lowest: compounds 1, 3 and 4 (each within the scatter of the next); then compound 2.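

The open-chain amine behaves like the two saturated rings in this assay: the diethylamino group stays within the scatter of pyrrolidin-1-yl (a 1.3-fold higher number from compound 3 to compound 4 (0.12 log units; within the scatter)) and of piperidin-1-yl (a 1.4-fold higher number from compound 1 to compound 4 (0.15 log units; within the scatter)), so none of the three amine ends on the benzyl-bearing compounds can be told apart at this position. Within the data shown here, compound 4 also gives the first single-place comparison with compound 2, and here phenyl in place of hydrogen on a saturated chain carbon bound to an oxygen on an aromatic ring gives a modest step beyond the scatter (a 4.1-fold lower number from compound 2 to compound 4 (0.62 log units; beyond the scatter)), the only step so far that does so. Of the two differences between compound 2 and compound 3, the amine exchange measured here stays within the scatter, which leaves the phenyl exchange as the one with a visible size, though no measurement shown accounts for either result.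

The compounds shown leave open whether an amine end carrying a second hetero atom, such as morpholine, or a primary amine would stay within the same scatter. They also leave open how a shorter or longer chain before the amine, or a chlorine on the added phenyl, would read in this assay.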